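A few compounds are considered here, and "the series" means these few. Any claim that something is new, unique, unknown or untested is made for them only; others in the source may bear on it.

Measured compounds:
compound 1 `O=C1CN=C(NC[C@@H]2CCCc3cc(S(=O)(=O)c4cccc(F)c4)ccc32)N1`: in an assay on isolated protein for displacement of a labelled ligand from 5-hydroxytryptamine receptor 6 (Homo sapiens) (a higher number here means a weaker inhibitor, a lower number a stronger inhibitor), compound 1 gives 0.1 nM
compound 2 `O=C(NC[C@@H]1CCCc2cc(S(=O)(=O)c3cccc(F)c3)ccc21)c1ncc[nH]1`: compound 2 gives 15.9 nM
compound 3 `NC(=O)NC[C@@H]1CCCc2cc(S(=O)(=O)c3cccc(F)c3)ccc21`: compound 3 gives 0.2 nM

Compound 3 stands second of the three numbers; its gap to compound 1 is within the scatter (a 2.0-fold higher number from compound 1 to compound 3 (0.30 log units; within the scatter)), whereas the step of an 80-fold lower number from compound 2 to compound 3 (1.90 log units; beyond the scatter) is large. Compound 4 `CC(C)(C)C(=O)NC[C@@H]1CCCc2cc(S(=O)(=O)c3cccc(F)c3)ccc21` differs from compound 3 by tert-butyl in place of amino on a carbonyl carbon. Among the measured compounds shown here, no measured step exchanges amino for an alkyl group on this carbonyl carbon. For the measured compounds named here, the only step at the carbonyl carbon, an 80-fold lower number from compound 2 to compound 3 (1.90 log units; beyond the scatter), shows the amino-bearing carbonyl as the stronger end, and a 2.0-fold higher number from compound 1 to compound 3 (0.30 log units; within the scatter) shows compound 1 and compound 3 within the scatter of each other. Removing the amino is therefore expected to raise the number by a moderate step of a 5.0-fold higher number from compound 3 to compound 4 (0.70 log units; beyond the scatter). Compound 4 is estimated at 1 nM, with a range from 0.2 nM to 10 nM.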

Compound 4, inhibition constant: 3.98 nM
Estimate against measurement, compound 4: 4.0-fold (0.60 log units) below; low and high end bracket the measured number.
By their numbers in this assay, from the lowest: compounds 1 and 3 (each within the scatter of the next); then compound 4; then compound 2.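

Putting tert-butyl in place of amino on the carbonyl carbon gives a large rise in the number (a 20-fold higher number from compound 3 to compound 4 (1.30 log units; beyond the scatter)), so the amino-bearing carbonyl is ahead of an all-carbon group as well as of 1H-imidazol-2-yl. Of these two carbon groups on the carbonyl carbon, tert-butyl gives the lower number (a 4.0-fold lower number from compound 2 to compound 4 (0.60 log units; beyond the scatter)), though the ring-bearing group on the amine nitrogen stays well ahead (a 40-fold higher number from compound 1 to compound 4 (1.60 log units; beyond the scatter)). Nothing at hand accounts for these gaps.

Still open, going by these compounds, is whether the rise comes from losing the amino or from tert-butyl itself. Methyl, methoxy or methylamino on the same carbonyl carbon would separate the two.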